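The source may hold more compounds than are shown below. What is called first, only, known or untested is meant among the compounds shown, and "the series" means these compounds.

Measured in a functional assay on HeLa cells (Homo sapiens) for cytotoxicity, read by MTT assay, with a stated time of 48 h; a lower number here means a stronger inhibitor, a higher number a weaker inhibitor:

- compound 1 `COC(=O)[C@@H](NC(=O)CSC1=CC(=O)c2cccc(OC)c2C1=O)C(C)C`: > 100000 nM
- compound 2 `COC(=O)[C@@H](NC(=O)CSC1=C(C)C(=O)c2ccccc2C1=O)C(C)C`: 20000 nM
- compound 3 `COC(=O)CNC(=O)CSC1=CC(=O)c2cccc(OC)c2C1=O`: > 100000 nM

Compound 3 gives > 100000 nM, which is a limit of the assay and not a number. Compound 3 thus stands at the limit of > 100000 nM in this assay, at which 2 of the 3 values shown sit.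

Compound 4 `CC[C@H](C)[C@H](NC(=O)CSC1=CC(=O)c2cccc(OC)c2C1=O)C(=O)OC` differs from compound 3 in one place: sec-butyl in place of hydrogen on a saturated chain carbon bound to an amide-type nitrogen and a carbonyl carbon. In words, sec-butyl replaces hydrogen on a saturated chain carbon bound to an amide-type nitrogen and a carbonyl carbon.

Among the compounds with values here, the one measured step at that place is a step that the two limits leave unreadable from compound 1 to compound 3. It offers no size to carry over. Compound 1, with isopropyl on that carbon, gives > 100000 nM, also a limit. Compound 2 alone gives a readable number, 20000 nM, but its core differs, so it sets no size for this change.

No step beyond the scatter is expected, and no direction can be foreseen: the expected change is a number no higher from compound 3 to compound 4 (the limit leaves the size open). The estimate for compound 4 is 100000 nM, with an expected range from 40000 nM to 250000 nM.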

Compound 4, half-maximal inhibitory concentration: 94500 nM
For compound 4 the middle estimate is 1.1-fold (0.02 log units) above the measured one; measured number inside the range.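

On the saturated chain carbon bound to an amide-type nitrogen and a carbonyl carbon, sec-butyl in place of hydrogen gives an at least 1.0-fold lower number from compound 3 to compound 4 (0.02 log units; that floor lies within the scatter) in this assay, and the extra methyl that separates sec-butyl from isopropyl gives an at least 1.0-fold lower number from compound 1 to compound 4 (0.02 log units; that floor lies within the scatter). Compound 4 thus gives a readable number on the core it shares with compounds 1 and 3, so this position can carry sec-butyl and still give a value inside the range of the assay. The true size of both steps stays hidden, because compounds 1 and 3 each carry only a limit: the limit of > 100000 nM in this assay, at which 2 of the 4 values shown sit.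

The compounds shown leave open whether any group at this position can move the number beyond the scatter. A benzyl group or an amine-bearing chain there, or a carboxylic acid in place of the methyl ester, would test this on the same core.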